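Heteroaryl swap on the biaryl carbon of an imidazoline series

A few compounds are considered here, and "the series" means these few. Any claim that something is new, unique, unknown or untested is made for them only; others in the source may bear on it.

Measured so far:
- compound 1, `c1cnc(-c2ccccc2OCC2=NCCN2)nc1`, in a functional assay for activation of Alpha-1B adrenergic receptor (Homo sapiens), read by calcium flux (a lower number here means that less compound is needed, a higher number that more compound is needed for the effect), gives < 100000 nM, a limit of the assay
- compound 2, `c1ccc(-c2ccncn2)c(OCC2=NCCN2)c1`, in this assay gives < 100000 nM, a limit of the assay

Compound 2 therefore stands only at a limit, with no number behind it. Within the data shown here, the one measured step, a step that the two limits leave unreadable from compound 1 to compound 2, is not readable in size or direction, since both ends sit at the same limit, as recorded in the limit of < 100000 nM in this assay, at which 2 of the 2 values shown sit. Nothing further is known about where compound 2 lies within that range.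

Compound 3, `Cc1cnsc1-c1ccccc1OCC1=NCCN1`, differs from compound 2 in one place: 4-methyl-1,2-thiazol-5-yl in place of pyrimidin-4-yl on an aromatic carbon. Among the measured compounds shown here, the only measured step that bears on this change is the one from compound 1 to compound 2, and it gives no readable size, so no direction beyond the scatter can be drawn from it for this assay. The expectation for compound 3 is therefore a step that the limit leaves unreadable from compound 2 to compound 3, meaning no change that the data can resolve. Compound 3 is expected to give about 30000 nM, within 3000 nM to 100000 nM, with a fair chance that again only a limit is reported.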

Compound 3, half-maximal effective concentration: < 100000 nM
Compound 3 gave a limit, no number (the forecaster's own chance of this, stated with the estimate: 60%); the middle value does not contradict the limit.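

No step can be read among compound 1, compound 2 and compound 3 in this assay, since all three stand at a single limit rather than at numbers: the limit of < 100000 nM in this assay, at which 3 of the 3 values shown sit.

The compounds shown leave open whether pyrimidin-2-yl, pyrimidin-4-yl or 4-methyl-1,2-thiazol-5-yl on the aromatic carbon makes any difference to the concentration needed in this assay, and how the three would rank.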